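This account rests on a few compounds, and the source may have more. Where it says the series, first, only, none or still open, it means among the compounds named here.

Compound 1 `CC(=O)Nc1cccc(-c2ccc(C(=O)N(Cc3cccc(OCCCCCC(=O)O)c3)C(C)C)cc2)c1` carries a 3-acetamidophenyl group on an aromatic carbon of its core. In an ADME assay on Raji cells (Homo sapiens) for cytotoxicity, read by CellTiter-Glo and resazurin assay, with a stated time of 72 h (a lower number here means that less compound is needed, a higher number that more compound is needed for the effect), compound 1 gives only a limit, > 26000 nM. Compound 2 `CC(C)N(Cc1cccc(OCCCCCC(=O)O)c1)C(=O)c1ccc(-c2ccco2)cc1` has furan-2-yl in that place. In this assay compound 2 likewise gives only a limit, > 26000 nM. The step that the two limits leave unreadable from compound 1 to compound 2 therefore cannot be sized; what is seen is the limit of > 26000 nM in this assay, at which 2 of the 2 values shown sit. Compound 3 `COc1cc(F)cc(-c2ccc(C(=O)N(Cc3cccc(OCCCCCC(=O)O)c3)C(C)C)cc2)c1` is not yet measured; relative to compound 1 it changes as follows: 3-fluoro-5-methoxyphenyl in place of 3-acetamidophenyl on an aromatic carbon. Among the measured compounds shown here, the single measured step bears on this change only in showing that exchanging the group in this place has so far left both compounds at the limit. Compound 3 is therefore expected to remain in the same region, with a step that the limit leaves unreadable from compound 1 to compound 3 that is not expected to stand out beyond the scatter. The estimate for compound 3 in this assay is 35000 nM, ranging from 15000 nM to 120000 nM, most likely again reported as a limit.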

Compound 3, half-maximal effective concentration: > 26000 nM
Compound 3 ended at the assay's limit; the forecaster's own chance of this, stated with the estimate: 80%; the middle value lies beyond the limit too.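

Compound 3 gives only a limit in this assay, so the steps to it from compound 1 and compound 2 cannot be read: the limit of > 26000 nM in this assay, at which 3 of the 3 values shown sit.

The compounds shown leave open where the true values of all three lie, and whether exchanging the group in this place changes them at all.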